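Thiomethyl series on the shared core: cyclohexyl to tolyl swap

The source may hold more compounds than are shown below. What is called first, only, known or untested is meant among the compounds shown, and "the series" means these compounds.

Two members of this series have a reading in a functional assay on MCF7 cells (Homo sapiens) for inhibition, read by MTT assay, with a stated time of 72 h; a lower number here means a stronger inhibitor, a higher number a weaker inhibitor. Compound 1, `Cc1cc(Nc2ccn(Cc3ccccc3)n2)n2nc(SCc3ccc(Br)cc3)nc2n1`, gives 15800 nM in this assay. Compound 2, `Cc1cc(Nc2cc(-c3ccccc3)[nH]n2)n2nc(SCC3CCCCC3)nc2n1`, is reported in this assay only as a limit, > 50000 nM, not as a number. In this assay, compound 2 therefore sits at the weak end of what has been seen so far, on the line (the limit of > 50000 nM in this assay, at which 1 of the 2 values shown sits), while compound 1 returns a measured number.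

The next compound, compound 3, `Cc1ccc(CSc2nc3nc(C)cc(Nc4cc(-c5ccccc5)[nH]n4)n3n2)cc1`, has not yet been run in this assay. It differs from compound 2 in one place: 4-methylphenyl in place of cyclohexyl on a saturated chain carbon bound to a sulfur. The rest of the molecule, including the phenyl-bearing ring attached through the amine to the shared core, is kept.

Going by the values given here, no measured pair in this set shares this single change, so the size of the step is open. Compound 1 carries a benzyl-type sulfanyl group and returns a number in this assay, 15800 nM, which suggests that an aromatic ring at this position is tolerated. The expectation for the step from compound 2 to compound 3 is a modest gain, an at least 2.0-fold lower number from compound 2 to compound 3 (0.30 log units; that floor lies within the scatter), though a limit is still a real possibility. Compound 3 is estimated at 25000 nM in this assay, within a range from 8000 nM to 50000 nM.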

Compound 3, half-maximal inhibitory concentration: 7290 nM
Estimate against measurement, compound 3: 3.4-fold (0.54 log units) above; the measured number lies below the stated range.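

In this assay, 4-methylphenyl in place of cyclohexyl on a saturated chain carbon bound to a sulfur turns a reading without a number into a measured one, and the change gives an at least 6.8-fold lower number from compound 2 to compound 3 (0.83 log units; beyond the scatter). This is the only pair shown that differs in one place, and it shows that the group at this position alone can move the reading beyond the scatter while the phenyl-bearing ring on the amine stays fixed. Compound 2 is reported only as a limit, so the step has a floor but no known full size: the limit of > 50000 nM in this assay, at which 1 of the 3 values shown sits.

The pair changes the ring type and adds a methyl group in the same swap, so it cannot show whether the aromatic ring or the methyl group accounts for the step, and a plain benzyl group would separate the two. Also open, going by these compounds, is how this position responds to a group of a different kind, such as an amine or a carboxylic acid on the benzyl ring, or to a longer chain between the sulfur and the ring.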